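Cinnamamide aryl variation on a shared aminoquinoline-type core

The source may hold more compounds than are shown below. What is called first, only, known or untested is meant among the compounds shown, and "the series" means these compounds.

Measured so far:
compound 1 `CCCc1cc(N)c2cc(NC(=O)/C=C/c3ccc(Cl)cc3Cl)ccc2n1` — 6.6 nM
compound 2 `CC(C)(C)c1cc(N)c2cc(NC(=O)/C=C/c3ccc(C(F)(F)F)cc3)ccc2n1` — 0.3 nM

In an assay on isolated protein for displacement of a labelled ligand from melanin-concentrating hormone receptor 1 (Homo sapiens) (on this read-out lower numbers stand for stronger inhibition and higher numbers for weaker inhibition), compound 1 gives 6.6 nM, the highest of the two numbers recorded; compound 2 gives 0.3 nM, a gap beyond the scatter, but the two compounds differ at two sites at once, so nothing can be assigned to either change alone.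

Compound 3 `CCCc1cc(N)c2cc(NC(=O)/C=C/c3ccc(SC)cc3)ccc2n1` is still to be measured in this assay. It keeps the core of compound 1 and changes only the cinnamamide aryl group: 4-(methylsulfanyl)phenyl in place of 2,4-dichlorophenyl on a double-bonded chain carbon bound to a double-bonded chain carbon. Among the compounds with values here, both measured compounds carry a chlorine-free or chlorine-bearing phenyl on the same chain, and neither holds a methylsulfanyl group, so the step has no direct precedent. Given that compound 2 reaches 0.3 nM with a single substituent on that ring, a small move toward a lower number is expected, a 1.9-fold lower number from compound 1 to compound 3 (0.28 log units; within the scatter), though the step may stay within the scatter. Compound 3 is estimated at 3.5 nM, with a range from 0.8 nM to 14 nM.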

Compound 3, half-maximal inhibitory concentration: 9 nM
For compound 3 the middle estimate is 2.6-fold (0.41 log units) below the measured one, and the stated range covers the measured number.
By their numbers in this assay, from the lowest: compound 2; then compounds 1 and 3 (each within the scatter of the next).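

In this assay, 4-(methylsulfanyl)phenyl in place of 2,4-dichlorophenyl gives a 1.4-fold higher number from compound 1 to compound 3 (0.13 log units; within the scatter), so this exchange on the core of compound 1 produces no separation in the read-out. Within the data shown here, this is the first single-site comparison, and it shows that, on a double-bonded chain carbon bound to a double-bonded chain carbon, a chlorine-free aryl group with a sulfur-bearing substituent reads the same as the dichlorinated one within the scatter. Nothing available bears on why these two aryl groups read alike.

Going by these compounds, whether a carboxylic acid or a primary amine on that phenyl ring would stay in the same range remains open. Compound 2 at 0.3 nM still differs from the others at two sites, so the contribution of each site to its value also remains unassigned.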